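Methylsulfanyl for methanesulfonamido on a bile acid receptor agonist

This account rests on a few compounds, and the source may have more. Where it says the series, first, only, none or still open, it means among the compounds named here.

Compound 1 `CC(C)(C)c1ccc(C(=O)NCc2ccc(NS(C)(=O)=O)cc2)cc1`: 44 nM
Compound 2 `O=C(O)c1ccc(CNC(=O)c2cccc(-c3ccccc3)c2)cc1`: 670 nM
Compound 3 `CC(C)(C)c1ccc(C(=O)NCc2ccc(NC(=O)C(F)(F)F)cc2Cl)cc1`: 14 nM

In an assay on HeLa cells with Bile acid receptor (Homo sapiens) as the target, read by a luciferase reporter, with a stated time of 24 h (a higher number here means that more compound is needed for the effect, a lower number that less compound is needed), compound 1 gives 44 nM. Among the three measured compounds this is the second highest number: compound 3 sits nearest with a lower number, and compound 2 sits furthest with a higher number, both gaps beyond the scatter.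

Compound 4 `CSc1ccc(CNC(=O)c2ccc(C(C)(C)C)cc2)cc1` has not been measured. It differs from compound 1 in one place: methylsulfanyl in place of methanesulfonamido on an aromatic carbon. The methanesulfonamido group that leaves carries the only hydrogen-bond donor on that ring, and the methylsulfanyl group that enters carries none.

Among the compounds with values here, no step between two measured compounds isolates this change, so the expectation rests on the spread of the three numbers. Compound 3, with a trifluoroacetamido group at the corresponding place, gives 14 nM, while compound 2 gives 670 nM. The step from compound 1 to compound 4 is expected to be a modest rise in the number, a 3.4-fold higher number from compound 1 to compound 4 (0.53 log units; beyond the scatter), probably beyond the scatter but well short of the gap to compound 2. For compound 4 the estimate in this assay is 150 nM, with a range from 40 nM to 600 nM.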

Compound 4, half-maximal effective concentration: 100 nM
Beside the measured number, compound 4's estimate is 1.5-fold (0.18 log units) above it; the measured number falls inside the stated range.
By their numbers in this assay, from the lowest: compound 3; then compound 1; then compound 4; then compound 2.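

In this assay, methylsulfanyl in place of methanesulfonamido on an aromatic carbon, para to a large group, gives a 2.3-fold higher number from compound 1 to compound 4 (0.36 log units; beyond the scatter) and is the only step shown that isolates a change at this position. The earlier compounds shown here could not show this cost, and the step shows that the methanesulfonamido group can be replaced by a smaller group with no hydrogen-bond donor while compound 4 still gives 100 nM and the rise stays modest. Nothing available explains the rise, so it cannot be assigned to the lost donor, to the loss of heavy atoms or to any other difference between the two groups.

The compounds shown leave open how an amino group or a methoxy group at this place on the core of compound 1 would read, and with them whether the step follows the hydrogen-bond donor or the size of the group. Also open, from the compounds shown here alone, is where a methylsulfonyl group, which keeps the sulfur and both oxygens but has no nitrogen, would fall relative to compound 1 and compound 4.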